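Ethoxycarbonyl enters a series of three measured compounds

A few compounds are considered here, and "the series" means these few. Any claim that something is new, unique, unknown or untested is made for them only; others in the source may bear on it.

Measured in a functional assay on MDA-MB-231 cells (Homo sapiens) for antiproliferative activity, read by MTT assay, with a stated time of 72 h; on this read-out higher numbers stand for weaker inhibition and lower numbers for stronger inhibition:
- compound 1 `O=C(CCc1cccc2c1B(O)OC2)Nc1ccc(I)cc1`: 33000 nM
- compound 2 `Cc1ccc(NC(=O)CCc2cccc3c2B(O)OC3)cc1`: 1100 nM
- compound 3 `CC(C)(C)OC(=O)NCc1ccc(NC(=O)CCc2cccc3c2B(O)OC3)cc1`: 1300 nM

Compound 3, at 1300 nM, cannot be told apart from its nearest neighbour in the set: the data show a 1.2-fold higher number from compound 2 to compound 3 (0.07 log units; within the scatter). The large gaps all involve the iodo group, with a 30-fold lower number from compound 1 to compound 2 (1.48 log units; beyond the scatter) and a 25-fold lower number from compound 1 to compound 3 (1.40 log units; beyond the scatter).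

The next structure is compound 4 `CCOC(=O)c1ccc(NC(=O)CCc2cccc3c2B(O)OC3)cc1`, which carries ethoxycarbonyl in place of ((tert-butoxycarbonyl)amino)methyl on an aromatic carbon. Among the measured compounds shown here, no measured compound carries this group, so the evidence is indirect. Two very different groups at this place gave matching numbers, as a 1.2-fold higher number from compound 2 to compound 3 (0.07 log units; within the scatter) shows, which suggests no large change. Yet a 25-fold lower number from compound 1 to compound 3 (1.40 log units; beyond the scatter) shows that one group here can matter greatly, so the risk lies mainly towards higher numbers.

The expected change is small: a 1.9-fold higher number from compound 3 to compound 4 (0.28 log units; within the scatter). For compound 4 the estimate in this assay is 2500 nM, with an expected range from 700 nM to 12000 nM.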

Compound 4, half-maximal inhibitory concentration: > 100000 nM
Compound 4: a limit, no number; the forecaster's own chance of this, stated with the estimate: 3%; middle value at least 40-fold (1.60 log units) from the limit.
By their numbers in this assay, from the lowest: compounds 2 and 3 (each within the scatter of the next); then compound 1. At a limit, above all of these: compound 4.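

Ethoxycarbonyl shows that a group on this aromatic carbon can do more than iodo did: the change gives an at least 3.0-fold higher number from compound 1 to compound 4 (0.48 log units; beyond the scatter). The earlier compounds had shown methyl and ((tert-butoxycarbonyl)amino)methyl giving matching numbers, but this place does not accept every group that leaves iodo behind, as seen in an at least 76-fold higher number from compound 3 to compound 4 (1.88 log units; beyond the scatter) and in an at least 90-fold higher number from compound 2 to compound 4 (1.95 log units; beyond the scatter). In this assay the result for compound 4 is a limit and not a number: the limit of > 100000 nM in this assay, at which 1 of the 4 values shown sits.

The compounds shown leave open how far beyond that limit compound 4 lies, so each of these steps gives only a minimum size. They also leave open whether a carboxylic acid, a primary amide or a simple acetyl group at this place would fall with ethoxycarbonyl or with methyl.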